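The source may hold more compounds than are shown below. What is called first, only, known or untested is meant among the compounds shown, and "the series" means these compounds.

Measured values in an ADME assay on microsomes from liver (Homo sapiens) for metabolic stability; on this read-out lower numbers stand for slow clearance and higher numbers for fast clearance:
Compound 1 `CC(C)n1cc(-c2ccnc3[nH]c(C4CCN(CC(=O)N5CCCC5)CC4)cc23)ccc1=O`: 45 uL/min
Compound 2 `CC(C)n1nc(-c2ccnc3[nH]c(C4CCN(CC(=O)N(C)C)CC4)cc23)ccc1=O`: 13 uL/min
Compound 3 `CC(C)n1cc(-c2ccnc3[nH]c(C4CCN(CC(=O)N5CCCCC5)CC4)cc23)ccc1=O`: > 300 uL/min, a limit of the assay

Compound 2 stands lowest of the two numbers in this assay; the nearest number is that of compound 1, which lies higher and beyond the scatter. The value of compound 3 is a limit, (the limit of > 300 uL/min in this assay, at which 1 of the 3 values shown sits). Compound 4 `COc1cc(=O)n(C)cc1-c1ccnc2[nH]c(C3CCN(CC(=O)N(C)C)CC3)cc12` differs from compound 2 in one place: a group of 10 heavy atoms (7 carbon, 1 nitrogen, 2 oxygen; one six-membered aromatic ring with 1 hetero atom) in place of a group of 10 heavy atoms (7 carbon, 2 nitrogen, 1 oxygen; one six-membered aromatic ring with 2 hetero atoms), on an aromatic carbon, on an aromatic carbon of a six-membered aromatic ring with 1 nitrogen, part of a fused or bridged system of two rings, opposite the ring nitrogen. Within the data shown here, the only measured step, an at least 6.6-fold higher number from compound 1 to compound 3 (0.82 log units; beyond the scatter), concerns a change on a carbonyl carbon and not this place, so it does not bear on the step to compound 4. Compounds 1 and 2 differ both at this ring and at the amide, so their two values alone cannot separate the effect of the ring. Among the measured compounds shown here, with no step of the same kind measured, compound 4 is expected to move by a 1.7-fold higher number from compound 2 to compound 4 (0.23 log units; within the scatter), which is within the scatter. Compound 4 is therefore estimated at 22 uL/min, between 8 uL/min and 70 uL/min.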

Compound 4, intrinsic clearance in a liver preparation (reported as CLH), per the amount of preparation that the assay uses: < 3 uL/min
Compound 4 ended at the assay's limit (the forecaster's own chance of this, stated with the estimate: 5%); middle value at least 7.3-fold (0.86 log units) from the limit.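

With the amide side held the same, the group exchanged on the aromatic carbon opposite the ring nitrogen moves this assay clearly: an at least 4.3-fold lower number from compound 2 to compound 4 (0.63 log units; beyond the scatter). Among these compounds, until now, the only step changing a single place lay on a carbonyl carbon, so this is the first sign that the group at this place also matters for the read-out, with the change running towards the low end of the scale. For compound 4, the value < 3 uL/min is a limit of the assay: the limit of < 3 uL/min in this assay, at which 1 of the 4 values shown sits.

The two groups differ in several parts, so this one step cannot say whether the lost ring nitrogen, the methoxy group or the methyl on the ring nitrogen in place of isopropyl carries the change. On these data alone, it also remains open whether an ethoxy group would do the same as the methoxy group, and whether the new group acts alike with the pyrrolidin-1-yl and piperidin-1-yl amides.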